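The source may hold more compounds than are shown below. What is called first, only, known or untested is meant among the compounds shown, and "the series" means these compounds.

- Compound 1 `CC(=O)Nc1nc2ccc(-c3cnc(Cl)c(NS(=O)(=O)c4ccc(C)cc4)c3)cn2n1`: 2650 nM
- Compound 2 `COc1ncc(-c2ccc3nc(NC(C)=O)nn3c2)cc1NS(=O)(=O)c1ccc(Cl)cc1`: 740 nM

In a functional assay on HCT-116 cells (Homo sapiens) for antiproliferative activity, read by MTT assay, with a stated time of 48 h (a lower number here means a stronger inhibitor, a higher number a weaker inhibitor), compound 2 has the lower of the two numbers at 740 nM, and its gap to compound 1 lies beyond the scatter. Compound 3 `COc1ncc(-c2ccc3nc(NC(C)=O)nn3c2)cc1NS(=O)(=O)c1ccc(C2CC2)cc1` changes compound 2 in one place: cyclopropyl in place of chloro on an aromatic carbon. Cyclopropyl stands in place of chloro on an aromatic carbon, para to a large group. Among the compounds with values here, no measured pair shows this change alone, so the expectation is cautious. The expected step, a 1.1-fold higher number from compound 2 to compound 3 (0.03 log units; within the scatter), stays within the scatter, with no firm direction. For compound 3 the estimated value is 800 nM, with an expected range from 300 nM to 2200 nM.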

Compound 3, half-maximal inhibitory concentration: 2220 nM
Beside the measured number, compound 3's estimate is 2.8-fold (0.44 log units) below it; the measured number lies above the stated range.
By their numbers in this assay, from the lowest: compound 2; then compounds 3 and 1 (each within the scatter of the next).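

In this assay, cyclopropyl in place of chloro on the aromatic carbon para to a large group gives a 3.0-fold higher number from compound 2 to compound 3 (0.48 log units; beyond the scatter), a step beyond the scatter. This single-place comparison shows that the position is not indifferent to its substituent, and that chloro gives the lower number of these two groups. Nothing available here explains the rise.

A single step sets no trend at this position. As far as these compounds go, whether an amine or a longer chain there would match or improve on chloro remains open.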